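A few compounds are considered here, and "the series" means these few. Any claim that something is new, unique, unknown or untested is made for them only; others in the source may bear on it.

Within the data shown here, in a functional assay with Rattus norvegicus as the target (on this read-out higher numbers stand for weaker inhibition and lower numbers for stronger inhibition), compound 1 `O=C(/C=C/c1ccncc1)c1cccc(Cl)c1` gives 69000 nM, the only actual number among the two values shown. Compound 2 `O=C(c1ccccc1)c1ccccc1-c1cccnc1` is recorded in this assay only as a limit, > 100000 nM, and not as a number. That value sits at the limit of > 100000 nM in this assay, at which 1 of the 2 values shown sits. Among the measured compounds shown here, compound 1 holds the sole number and compound 2 sits at a limit. For the measured compounds named here, no step between measured compounds can be drawn from these data, and nothing is known about how a change of one small group for another shifts the read-out here. Compound 3 `N#Cc1cccc(C(=O)/C=C/c2ccncc2)c1` differs from compound 1 in one place: cyano in place of chloro on an aromatic carbon. Going by the values given here, with no measured pair to lean on, the expected step is none beyond the scatter, expressed as a 1.2-fold higher number from compound 1 to compound 3 (0.06 log units; within the scatter). Compound 3 is accordingly estimated at 80000 nM in this assay, within a range from 30000 nM to 200000 nM, with a real chance that only a limit is reported.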

Compound 3, half-maximal inhibitory concentration: 85000 nM
For compound 3 the middle estimate is 1.1-fold (0.03 log units) below the measured one, within the range that was stated.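

Cyano in place of chloro on an aromatic carbon, meta to a large group, gives the first step that can be read in this assay: a 1.2-fold higher number from compound 1 to compound 3 (0.09 log units; within the scatter). At this position the read-out therefore does not separate the two groups, even though cyano, unlike chloro, counts as a hydrogen-bond acceptor and holds a triple bond. Nothing measured here bears on why the two groups read alike.

One exchange leaves open whether any group on this aromatic carbon can move the number beyond the scatter, for instance an amine, a carboxylic acid or a longer chain. Going by these compounds, it is also open whether a change elsewhere on the core of compound 1 would shift this assay more than this one did.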